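Aryl variation on the shared core: compound 3 to compound 4

The source may report more compounds than this note shows. Statements on the series, on what has been measured and on what is new or still open speak of the compounds shown alone.

Compound 3 `CC(C)(C)c1ccc(-c2nc3sccn3c2/C=N/OCc2ccc(Cl)c(Cl)c2)cc1` carries a 4-(tert-butyl)phenyl group on the shared core. In an assay on HepG2 cells for agonist activity at nuclear receptor subfamily 1 group I member 3 (Homo sapiens), read by a luciferase reporter, with a stated time of 23 h (on this read-out lower numbers stand for an effect already at smaller amounts and higher numbers for an effect only at larger amounts of compound), compound 3 gives 2400 nM, the highest number of the three measured. Compound 1 `Cc1ccc(-c2nc3sccn3c2/C=N/OCc2ccc(Cl)c(Cl)c2)cc1` gives 490 nM in this assay, and compound 2 `Clc1ccc(CO/N=C/c2c(-c3ccc4ccccc4c3)nc3sccn23)cc1Cl` gives 380 nM; the step of a 1.3-fold lower number from compound 1 to compound 2 (0.11 log units; within the scatter) stays within the scatter, whereas a 4.9-fold higher number from compound 1 to compound 3 (0.69 log units; beyond the scatter) and a 6.3-fold higher number from compound 2 to compound 3 (0.80 log units; beyond the scatter) both stand beyond it. Compound 4 `Clc1cccc(-c2nc3sccn3c2/C=N/OCc2ccc(Cl)c(Cl)c2)c1` differs from compound 3 by 3-chlorophenyl in place of 4-(tert-butyl)phenyl on an aromatic carbon. Among the measured compounds shown here, no measured pair carries a 3-chlorophenyl group, so the steps that bear on this change are only a 4.9-fold higher number from compound 1 to compound 3 (0.69 log units; beyond the scatter) and a 6.3-fold higher number from compound 2 to compound 3 (0.80 log units; beyond the scatter), both of which place the 4-(tert-butyl)phenyl compound at the high end. The group that leaves in compound 4 is the one shared by both of those steps, so a move back toward the numbers of compound 1 and compound 2 is expected. The step of a 4.0-fold lower number from compound 3 to compound 4 (0.60 log units; beyond the scatter) is therefore estimated to fall beyond the scatter in the downward direction. The size remains uncertain, since compound 1 at 490 nM and compound 2 at 380 nM carry groups other than 3-chlorophenyl. Compound 4 is estimated at 600 nM, within 200 nM to 2000 nM, in this assay.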

Compound 4, half-maximal effective concentration: 1100 nM
For compound 4 the middle estimate is 1.8-fold (0.26 log units) below the measured one; the measured number falls inside the stated range.
By their numbers in this assay, from the lowest: compounds 2 and 1 (each within the scatter of the next); then compound 4; then compound 3.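

In this assay, 3-chlorophenyl in place of 4-(tert-butyl)phenyl brings the number only part of the way back, with a 2.2-fold lower number from compound 3 to compound 4 (0.34 log units; beyond the scatter), while a 2.2-fold higher number from compound 1 to compound 4 (0.35 log units; beyond the scatter) and a 2.9-fold higher number from compound 2 to compound 4 (0.46 log units; beyond the scatter) remain on the other side. The earlier compounds shown here set only 4-(tert-butyl)phenyl apart, but 3-chlorophenyl now also separates from both 4-methylphenyl and naphthalen-2-yl, so across these four compounds this aromatic carbon of the five-membered ring gives an intermediate level as well as the two seen before. No measurement is available that accounts for the differences among these aryl groups.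

The compounds shown leave open how a plain phenyl, a phenyl carrying an amine or a phenyl carrying a carboxylic acid would sit relative to these four numbers, and so whether the chlorine itself has any part in the intermediate level. From the compounds shown here alone, all four compounds also share the rest of the structure, so it remains open whether these steps would hold with a different group in place of the dichlorinated benzyl part.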